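Compound 3: widening the ether chain of compound 2

This account rests on a few compounds, and the source may have more. Where it says the series, first, only, none or still open, it means among the compounds named here.

- compound 1 `O=c1cc(N2CCNCC2)c2ccc(OCc3ccccc3)cc2o1` gives 16300 nM
- compound 2 `CCCOc1ccc2c(N3CCNCC3)cc(=O)oc2c1C` gives 2950 nM

In a functional assay on a cell-free system (plasma, Homo sapiens) for inhibition, with Plasma (Rattus norvegicus) as the target (on this read-out higher numbers stand for weaker inhibition and lower numbers for stronger inhibition), compound 2 gives 2950 nM and so holds the lower of the two numbers. Compound 1 gives 16300 nM. The gap between these two numbers lies beyond the scatter. Compound 3 `Cc1c(OCC2CCCN(C)C2)ccc2c(N3CCNCC3)cc(=O)oc12` differs from compound 2 by 1-methylpiperidin-3-yl in place of ethyl on a saturated chain carbon bound to an oxygen on an aromatic ring on the shared core: 1-methylpiperidin-3-yl in place of ethyl on a saturated chain carbon bound to an oxygen on an aromatic ring. Among the compounds with values here, no measured pair shows a comparable change, so no shift beyond the scatter is expected in this assay and the range stays wide. The expected 1.0-fold higher number from compound 2 to compound 3 (0.01 log units; within the scatter) is small and has no firm direction. The estimate for compound 3 is 3000 nM (expected range 800 nM to 11000 nM) in this read-out.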

Compound 3, half-maximal inhibitory concentration: 4700 nM
The estimate for compound 3 lay 1.6-fold (0.19 log units) below the measured number; measured number inside the range.
By their numbers in this assay, from the lowest: compounds 2 and 3 (each within the scatter of the next); then compound 1.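

On a saturated chain carbon bound to an oxygen on an aromatic ring, 1-methylpiperidin-3-yl in place of ethyl gives a 1.6-fold higher number from compound 2 to compound 3 (0.20 log units; within the scatter) in this assay. Within the data shown here, this position therefore takes a group of 7 heavy atoms, with a six-membered non-aromatic ring, in place of one of 2 without a shift beyond the scatter, something no earlier pair could show. Nothing at hand bears on this result.

On these data alone, whether the ring nitrogen contributes remains open. A cyclohexyl group or a carboxylic acid at this carbon would test how far the tolerance extends.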